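Swapping Phenyl for Pyridin-2-yl on a Carbamate Chain

The source may hold more compounds than are shown below. What is called first, only, known or untested is meant among the compounds shown, and "the series" means these compounds.

Compound 1 `CCCCCCCCOC(=O)N[C@H]1CNC1=O`: 37 nM
Compound 2 `O=C(N[C@H]1CNC1=O)OCCCCc1ccccc1`: 1110 nM
Compound 3 `COc1ccc(CCCCOC(=O)N[C@H]2CNC2=O)cc1`: 520 nM

Three compounds share a core and differ only in the tail of the carbamate chain. In an assay on HEK293 cells for inhibition of N-acylethanolamine-hydrolyzing acid amidase (Homo sapiens), read by fluorescence, with stated times of 10 min and 50 min (a lower number here means a stronger inhibitor, a higher number a weaker inhibitor), compound 2 gives the highest of the three numbers, that is, it is the weakest inhibitor of the set: compound 3 lies closest to it, and compound 1 lies furthest away.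

Compound 4 `O=C(N[C@H]1CNC1=O)OCCCCc1ccccn1` has not yet been measured. It differs from compound 2 in one place: pyridin-2-yl in place of phenyl on a saturated chain carbon, four bonds along the chain from an oxygen next to a carbonyl group.

Within the data shown here, no measured step swaps one aromatic ring for another, so the guidance is indirect. The step of a 30-fold higher number from compound 1 to compound 2 (1.48 log units; beyond the scatter) shows that the tail matters greatly, while a 2.1-fold lower number from compound 2 to compound 3 (0.33 log units; beyond the scatter) shows that a small change on the ring itself shifts the number only modestly. A ring-for-ring swap of the same size seems more like the second case, so no step beyond the scatter is expected in this assay, in either direction.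

Compound 4 is therefore estimated at 1300 nM, with a range from 400 nM to 4000 nM.

The expected step is a 1.2-fold higher number from compound 2 to compound 4 (0.07 log units; within the scatter).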

Compound 4, half-maximal inhibitory concentration: 30700 nM
Compound 4: the middle estimate sits 24-fold (1.37 log units) below what was measured; measured number outside the range, above it.
By their numbers in this assay, from the lowest: compound 1; then compound 3; then compound 2; then compound 4.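

In this assay, the step of a 28-fold higher number from compound 2 to compound 4 (1.44 log units; beyond the scatter) shows that pyridin-2-yl in place of phenyl is far from a neutral swap at this place on the chain, even though both are six-membered aromatic rings of 6 heavy atoms. Among these compounds, the rings differ in only one ring atom, a nitrogen for a carbon, so what counts here is the make-up of the ring and not only the presence of a ring. The step of an 830-fold higher number from compound 1 to compound 4 (2.92 log units; beyond the scatter) then separates compound 4 very widely from the butyl-ended tail of compound 1. Nothing available explains this loss.

On these data alone, whether pyridin-3-yl or pyridin-4-yl would behave like pyridin-2-yl remains open, as does the outcome for a saturated cyclohexyl ring at the same place. As far as these compounds go, it is also open whether a methoxy group on the pyridin-2-yl ring would shift the number as it does on the phenyl ring.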